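The source may hold more compounds than are shown below. What is called first, only, known or untested is meant among the compounds shown, and "the series" means these compounds.

The measured compounds:
compound 1, `O=C(Nc1ccc(Sc2nc3ccccc3s2)c(Cl)c1)c1ccccc1O`: 64000 nM
compound 2, `O=C(Nc1ccc(Sc2nc3ccccc3s2)c(Cl)c1)c1cccc(Br)c1`: > 100000 nM
compound 3, `COc1c(Br)cc(Br)cc1C(=O)Nc1ccc(Sc2nc3ccccc3s2)c(Cl)c1`: > 100000 nM

In an ADME assay on HEK293 cells (Homo sapiens) for cytotoxicity, read by reporter gene assay and resazurin assay, with a stated time of 48 h (on this read-out higher numbers stand for lower toxicity in this test and lower numbers for higher toxicity in this test), compound 3 stands only at a limit of the assay, > 100000 nM. Compound 2 sits at a limit as well, > 100000 nM. Compound 1 alone gives a number, 64000 nM. Two of the three values thus rest at the limit of > 100000 nM in this assay, at which 2 of the 3 values shown sit, so compound 3 cannot be placed more closely than that. The measured steps that lead to compound 3 are an at least 1.5-fold higher number from compound 1 to compound 3 (0.19 log units; that floor lies within the scatter) and a step that the two limits leave unreadable from compound 2 to compound 3; the first is only a floor that lies within the scatter, the second cannot be read at all. Compound 4 is `O=C(Nc1ccc(Sc2nc3ccccc3s2)c(Cl)c1)c1ccccc1`. It differs from compound 3 in one place: a group of 6 heavy atoms (6 carbon; one six-membered aromatic ring of carbon only) in place of a group of 10 heavy atoms (7 carbon, 1 oxygen, 2 bromine; one six-membered aromatic ring of carbon only), on a carbonyl carbon. The shown steps give no movement beyond the scatter, and compound 1, which carries a different group on the same carbonyl carbon, also lies within the scatter of the limit. Compound 4 is therefore expected to stay near the limit, with a number no higher from compound 3 to compound 4 (the limit leaves the size open) as the expected step. The estimate for compound 4 is 100000 nM, ranging from 50000 nM to 200000 nM.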

Compound 4, half-maximal cytotoxic concentration: 90000 nM
Estimate against measurement, compound 4: 1.1-fold (0.05 log units) above, and the stated range covers the measured number.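

In this assay, within the data shown here, the phenyl group on the carbonyl carbon gives a number rather than a limit, so hydrogen in place of hydroxy yields the first step with a measured number at both ends: a 1.4-fold higher number from compound 1 to compound 4 (0.15 log units; within the scatter). Hydrogen in place of bromo gives an at least 1.1-fold lower number from compound 2 to compound 4 (0.04 log units; that floor lies within the scatter), and phenyl in place of the larger group of compound 3 gives an at least 1.1-fold lower number from compound 3 to compound 4 (0.04 log units; that floor lies within the scatter). Those two steps are only floors, so their true size stays unknown, and the hydroxy step alone is fully readable: the limit of > 100000 nM in this assay, at which 2 of the 4 values shown sit.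

The compounds shown leave open how far compound 2 and compound 3 actually lie from compound 4. They also leave open whether an amine or a carboxylic acid on this phenyl ring would move the read-out beyond the scatter.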